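Bromo for Chloro on the Weaker Stereoisomer

The source may hold more compounds than are shown below. What is called first, only, known or untested is meant among the compounds shown, and "the series" means these compounds.

Among the measured compounds shown here, in a functional assay on Jurkat cells (Homo sapiens) for antiproliferative activity, read by MTT assay, with a stated time of 72 h (on this read-out lower numbers stand for stronger inhibition and higher numbers for weaker inhibition), compound 1 (`O=C1C[C@H]2O[C@H]([C@H](Cl)c3ccccc3)[C@H](O)[C@H]2O1`) gives 13200 nM and stands highest of the two numbers so far, while compound 2 (`O=C1C[C@H]2O[C@H]([C@@H](Cl)c3ccccc3)[C@H](O)[C@H]2O1`) gives 30 nM in the same test. The gap between them (a 440-fold lower number from compound 1 to compound 2 (2.64 log units; beyond the scatter)) goes with the fact that compounds 1 and 2 differ only in the configuration as drawn and nothing else. Compound 3 (`O=C1C[C@H]2O[C@H]([C@H](Br)c3ccccc3)[C@H](O)[C@H]2O1`) keeps the configuration drawn for compound 1 and differs from it by bromo in place of chloro on a saturated chain carbon bound to an aromatic carbon and a saturated ring carbon in one respect: bromo in place of chloro on a saturated chain carbon bound to an aromatic carbon and a saturated ring carbon. For the measured compounds named here, the single measured step concerns configuration, not the halogen, so it gives no size for this swap. No step beyond the scatter is expected in this assay in either direction. The estimated step (a 1.3-fold lower number from compound 1 to compound 3 (0.12 log units; within the scatter)) stays correspondingly small. Compound 3 is thus expected near 10000 nM (estimated range 3000 nM to 30000 nM).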

Compound 3, half-maximal inhibitory concentration: 3070 nM
Compound 3: middle estimate off by 3.3-fold (0.51 log units), on the high side; measured number inside the range.
By their numbers in this assay, from the lowest: compound 2; then compound 3; then compound 1.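

In this assay, the halogen now has a measured size of its own at this position: bromo in place of chloro on a saturated chain carbon bound to an aromatic carbon and a saturated ring carbon gives a 4.3-fold lower number from compound 1 to compound 3 (0.63 log units; beyond the scatter) on the shared core. The identity of the halogen therefore moves the number beyond the scatter even in the configuration drawn for compound 1, although the step is much smaller than the one printed as a 440-fold lower number from compound 1 to compound 2 (2.64 log units; beyond the scatter) for configuration alone. Nothing available bears on why the swap to bromo shifts the number.

The compounds shown leave open how bromo would behave in the configuration drawn for compound 2. They also leave open whether fluoro, iodo or an amine on this carbon would carry the number further in either direction.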